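Amide-nitrogen substituent swap on the shared core

A few compounds are considered here, and "the series" means these few. Any claim that something is new, unique, unknown or untested is made for them only; others in the source may bear on it.

Two compounds of the series carry a measurement in an ADME assay on HaCaT cells (Homo sapiens) for inhibition; on this read-out lower numbers stand for stronger inhibition and higher numbers for weaker inhibition. Compound 1 `COc1cc(-c2cc(C(=O)O)c3ccccc3n2)ccc1OCC(=O)Nc1cccc(Cl)c1` gives 192000 nM, and compound 2 `COc1cc(-c2cc(C(=O)O)c3ccccc3n2)ccc1OCC(=O)Nc1cccc(C(F)(F)F)c1` gives 160000 nM. Within the data shown here, the single step between them, a 1.2-fold lower number from compound 1 to compound 2 (0.08 log units; within the scatter), leaves the two values within the scatter of each other, so compound 2 stands as the lower of two numbers without being separable from compound 1.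

Compound 3 `COc1cc(-c2cc(C(=O)O)c3ccccc3n2)ccc1OCC(=O)NCc1cccnc1` is reached from compound 2 by the change ((pyridin-3-yl)methyl in place of 3-(trifluoromethyl)phenyl on an amide-type nitrogen). Among the measured compounds shown here, no measured step touches the amide-nitrogen substituent in this way: the one step known swaps one group on the aromatic ring for another and stays within the scatter, so it carries no information on whether a heteroaromatic methyl group in place of the aryl group moves this read-out at all. The expectation for compound 3 therefore rests on compound 2 alone, and the step of a 1.1-fold higher number from compound 2 to compound 3 (0.05 log units; within the scatter) is estimated as no change beyond the scatter, in no preferred direction. Compound 3 is expected to give about 180000 nM in this assay, with a range from 70000 nM to 450000 nM.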

Compound 3, half-maximal inhibitory concentration: > 300000 nM
Compound 3: only a limit was reported; the forecaster's own chance of this, stated with the estimate: 30%; at least 1.6-fold (0.22 log units) between middle value and limit.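

In this assay compound 3 carries a limit of the assay and not a number: > 300000 nM. At the amide-type nitrogen, the replacement of the aryl group by (pyridin-3-yl)methyl reads as an at least 1.8-fold higher number from compound 2 to compound 3 (0.27 log units; that floor lies within the scatter), and as an at least 1.5-fold higher number from compound 1 to compound 3 (0.19 log units; that floor lies within the scatter). This is the first change seen at this position; it gives no lower number than the aryl compounds, though neither floor establishes a shift beyond the scatter, and the true size of both steps stays unresolved at the ceiling of the read-out: the limit of > 300000 nM in this assay, at which 1 of the 3 values shown sits.

The compounds shown leave open whether the ring nitrogen of the pyridine or the extra carbon link on the amide-type nitrogen matters for this read-out, since the change brings in both at once; a plain benzyl group on that nitrogen, or a pyridin-3-yl group attached to it directly, would separate the two. Also open, on these data alone, is whether any group at this position, such as a basic aminoalkyl chain or a cyclohexyl ring, brings the number clearly down from the level of the aryl amides.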